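Swapping Dichlorophenyl for Methylpyridinyl on a Shared Core

The compounds below may be only part of what the source reports. "The series", "measured", "known", "first", "only" and "open" are said of these compounds alone.

Going by the values given here, compound 3 `N=C1S/C(=C\c2ccc(OCc3ccccc3)cc2)C(=O)N1c1ccc(Cl)cc1Cl` holds the second highest of the three numbers measured so far in an ADME assay on RAW264.7 cells (Mus musculus) for cytotoxicity, read by MTT assay, with a stated time of 48 h, tested at 50 uM (on this read-out higher numbers stand for more inhibition at the one concentration tested (going by the name of the read-out) and lower numbers for less inhibition), where compound 3 gives 13.8%. Its nearest neighbour is compound 2 `N=C1S/C(=C\c2ccc(OCc3ccccc3)cc2)C(=O)N1c1ccc([N+](=O)[O-])cc1`, which gives 17.3%; the step of a number 3.5 percentage points lower from compound 2 to compound 3 (within the scatter) stays within the scatter. The furthest is compound 1 `N=C1S/C(=C\c2ccc(OCc3ccccc3)cc2)C(=O)N1c1ccc(Br)cc1`, which gives 7.83%, and the step of a number 6 percentage points higher from compound 1 to compound 3 (within the scatter) also stays within the scatter. Compound 4 `Cc1cccc(N2C(=N)S/C(=C\c3ccc(OCc4ccccc4)cc3)C2=O)n1` has not yet been measured. It differs from compound 3 in one place: 6-methylpyridin-2-yl in place of 2,4-dichlorophenyl on an amide-type nitrogen in a ring. Among the compounds with values here, no measured step exchanges the group on the amide-type nitrogen for a ring with a hetero atom. The two steps that do alter that group, a number 6 percentage points higher from compound 1 to compound 3 (within the scatter) and a number 3.5 percentage points lower from compound 2 to compound 3 (within the scatter), and the remaining step, a number 9.5 percentage points higher from compound 1 to compound 2 (within the scatter), were all within the scatter. The step of a number 0.2 percentage points higher from compound 3 to compound 4 (within the scatter) that this estimate means is therefore expected to stay within the scatter. Compound 4 is estimated at 14%, between 4% and 26%.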

Compound 4, a percentage reported as inhibition, at one concentration (the size of the read-out at that concentration, not a potency): 25.1%
Beside the measured number, compound 4's estimate is 11.1 percentage points below it; low and high end bracket the measured number.
By their numbers in this assay, from the lowest: compounds 1, 3, 2 and 4 (each within the scatter of the next, the first and the last beyond it).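

Going by these compounds alone, on the amide-type nitrogen in a ring, the change to 6-methylpyridin-2-yl is the first at this position to shift the read-out in this assay beyond the scatter, giving a number 11.3 percentage points higher from compound 3 to compound 4 (beyond the scatter) and a number 17.3 percentage points higher from compound 1 to compound 4 (beyond the scatter). Compound 2 goes against any reading that this group stands apart from every substituted phenyl group shown, with a number 7.8 percentage points higher from compound 2 to compound 4 (within the scatter). No measurement is at hand that would explain these steps.

The 6-methylpyridin-2-yl group brings its ring nitrogen and its methyl in together, and the compounds shown do not separate what each contributes. Also open, on these data alone, is what a phenyl ring carrying an amine or a carboxylic acid would give at this position in this assay.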